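This account rests on a few compounds, and the source may have more. Where it says the series, first, only, none or still open, it means among the compounds named here.

Working notes on the series. In a functional assay on CCRF-CEM cells (Homo sapiens) for inhibition, read by cell counting, with a stated time of 3 days (on this read-out lower numbers stand for stronger inhibition and higher numbers for weaker inhibition), compound 1 `Nc1cccc(-c2cn3nc(Cc4ccccc4)sc3n2)c1` gives 37000 nM. Compound 2 `COc1ccc(Cc2nn3cc(-c4cccc(N)c4)nc3s2)cc1` reaches only a limit of this assay, >= 250000 nM; this is the limit of >= 250000 nM in this assay, at which 1 of the 3 values shown sits. The change between them, (hydrogen in place of methoxy on an aromatic carbon), brings an at least 6.7-fold lower number from compound 2 to compound 1 (0.82 log units; beyond the scatter). Compound 3 `COc1cccc(-c2nn3cc(-c4cccc(N)c4)nc3s2)c1` likewise shows only a limit of this assay, > 250000 nM; this is the limit of > 250000 nM in this assay, at which 1 of the 3 values shown sits. The difference between the cores of compound 2 and compound 3 is not broken down here. Compound 4 `Nc1cccc(-c2cn3nc(-c4ccccc4)sc3n2)c1` has not yet been measured in this assay; it differs from compound 3 by hydrogen in place of methoxy on an aromatic carbon, the same kind of change as that from compound 2 to compound 1, but the place differs: meta to a large group rather than para to a large group. On these data alone, the starting point is unknown, as compound 3 shows only a limit. A step of an at least 2.5-fold lower number from compound 3 to compound 4 (0.39 log units; beyond the scatter) is expected, judged somewhat smaller than the measured step of an at least 6.7-fold lower number from compound 2 to compound 1 (0.82 log units; beyond the scatter), which does not give a full number. Compound 4 is estimated at 100000 nM, between 30000 nM and 250000 nM.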

Compound 4, half-maximal inhibitory concentration: 33000 nM
Estimate against measurement, compound 4: 3.0-fold (0.48 log units) above; the measured number falls inside the stated range.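

In this assay, hydrogen in place of methoxy again gives a lower number on the second core, with an at least 7.5-fold lower number from compound 3 to compound 4 (0.87 log units; beyond the scatter), and the two steps can be set side by side: the same change on two cores in this assay, an at least 6.7-fold lower number (0.82 log units; beyond the scatter) from compound 2 to compound 1 and an at least 7.5-fold lower number (0.87 log units; beyond the scatter) from compound 3 to compound 4; the limit leaves it open whether they differ. Both steps start from limits, so they show a shared direction across compounds 1 to 4 but no transferable size. Between the two cores without methoxy, phenyl in place of benzyl gives a 1.1-fold lower number from compound 1 to compound 4 (0.05 log units; within the scatter), so this pair does not separate them.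

The compounds shown leave open how far the result depends on losing methoxy in particular. A chloro group or a carboxylic acid at the same place on either core would bear on that question.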